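Swapping phenyl for tert-butyl on a carbonyl carbon

The compounds below may be only part of what the source reports. "The series", "measured", "known", "first", "only" and "open" are said of these compounds alone.

Measured in a physicochemical assay for pharmacokinetics, at pH 6; on this read-out higher numbers stand for a longer-lived compound and lower numbers for a shorter-lived compound:
Compound 1 `O=C(Sc1cccnc1C(=O)O)c1ccccc1`: 21.1 h
Compound 2 `O=C(Sc1cccnc1C(=O)O)c1ccc(C(F)(F)F)cc1`: 3 h
Compound 3 `O=C(Sc1cccnc1C(=O)O)c1ccc([N+](=O)[O-])cc1`: 1.4 h

Compound 1 stands highest of these three. Compound 4 `CC(C)(C)C(=O)Sc1cccnc1C(=O)O` has not been measured. Its difference from compound 1 is tert-butyl in place of phenyl on a carbonyl carbon. Two measured steps come closest: a 7.0-fold lower number from compound 1 to compound 2 (0.85 log units; beyond the scatter) and a 15-fold lower number from compound 1 to compound 3 (1.18 log units; beyond the scatter). Each replaces hydrogen on an aromatic carbon, and neither replaces the phenyl itself, so they show only how far the number can move. The direction is therefore a tentative call, a modest rise in this assay. The expected step is a 2.4-fold higher number from compound 1 to compound 4 (0.37 log units; beyond the scatter). For compound 4 the estimate is 50 h, with an expected range of 12 h to 200 h.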

Compound 4, half-life: 61.1 h
Compound 4: middle estimate off by 1.2-fold (0.09 log units), on the low side; measured number inside the range.
By their numbers in this assay, from the lowest: compound 3; then compound 2; then compound 1; then compound 4.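

The earlier steps shown here only added groups to the phenyl, and each lowered the number, whereas replacing the phenyl itself on the carbonyl carbon gives a 2.9-fold higher number from compound 1 to compound 4 (0.46 log units; beyond the scatter) in this assay. So at this position, the half-life does not depend on keeping an aromatic ring, and a group without a ring can take its place. No measurement here explains the rise. Going by these compounds, whether it comes from losing the ring or from tert-butyl itself remains open. Cyclohexyl or isopropyl on the same carbonyl carbon would help separate the two.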